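The source may report more compounds than this note shows. Statements on the series, on what has been measured and on what is new or still open speak of the compounds shown alone.

Compound 2 `CSc1nc(NCCCCCO)c2ccccc2n1` stands only at a limit in a functional assay on HT-29 cells (Homo sapiens) for cytotoxicity, read by MTT assay, with a stated time of 72 h; on this read-out lower numbers stand for higher toxicity in this test and higher numbers for lower toxicity in this test: compound 2 gives > 100000 nM. Compound 1 `CSc1nc(NCCCCc2ccccc2)c2ccccc2n1` likewise shows only a limit, since compound 1 gives > 100000 nM. Within the data shown here, the single step between them, a step that the two limits leave unreadable from compound 1 to compound 2, cannot be read from two limits. Compound 3 `CSc1nc(Nc2ccccc2)c2ccccc2n1` differs from compound 2 by phenyl in place of 5-hydroxypentyl on a nitrogen on an aromatic ring. No measured step bears on this change; all that is shown is the limit of > 100000 nM in this assay, at which 2 of the 2 values shown sit. Compound 3 is therefore expected to stay near that limit, an estimated step of a number no higher from compound 2 to compound 3 (the limit leaves the size open). The estimate for compound 3 is 100000 nM, with a range from 20000 nM to 300000 nM.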

Compound 3, concentration lethal to 50% of the cells: > 100000 nM
Compound 3: no number, only a limit (the forecaster's own chance of this, stated with the estimate: 60%); the middle value lies on the limit itself.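

No new step can be read between compound 2 and compound 3, since both stand only at a limit in this assay. The compounds shown leave open whether any change on the shared core alters toxicity in this assay.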